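Compound 3 to compound 4: a longer sulfanyl chain

The compounds below may be only part of what the source reports. "The series", "measured", "known", "first", "only" and "open" are said of these compounds alone.

Three compounds on the shared core have numbers in a functional assay on MV4-11 cells (Homo sapiens) for inhibition, read by resazurin assay, with a stated time of 72 h; on this read-out higher numbers stand for weaker inhibition of growth and lower numbers for stronger inhibition of growth. Compound 1 (`COc1ccc(Nc2nccc(-c3sc(SC)nc3C)n2)c(OC)c1`) gives 530 nM, compound 2 (`CNc1nc(C)c(-c2ccnc(Nc3ccc(OC)cc3OC)n2)s1`) gives 300 nM and compound 3 (`COc1ccc(Nc2nccc(-c3sc(N(C)C)nc3C)n2)c(OC)c1`) gives 170 nM. Compound 3 is separated from compound 1 but not from compound 2. The modest step is a 3.1-fold lower number from compound 1 to compound 3 (0.49 log units; beyond the scatter), while a 1.8-fold lower number from compound 1 to compound 2 (0.25 log units; within the scatter) and a 1.8-fold lower number from compound 2 to compound 3 (0.25 log units; within the scatter) both stay within the scatter.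

Compound 4 (`COc1ccc(Nc2nccc(-c3sc(SCCCN(C)C)nc3C)n2)c(OC)c1`) differs from compound 3 by (3-(dimethylamino)propyl)sulfanyl in place of dimethylamino on an aromatic carbon. In words, (3-(dimethylamino)propyl)sulfanyl stands in place of dimethylamino on an aromatic carbon. Among the measured compounds shown here, no measured compound carries a chain of this kind, so its contribution is untested. The closest evidence is a 3.1-fold lower number from compound 1 to compound 3 (0.49 log units; beyond the scatter), which, read backwards, suggests that a return to a sulfanyl group could move the number upward, towards the value of compound 1 at 530 nM. That reading is weak, as the two groups share only the sulfanyl link. The estimated step is a 1.8-fold higher number from compound 3 to compound 4 (0.25 log units; within the scatter), so a lean towards a higher number is expected, with no clear shift beyond the scatter. For compound 4 the estimated value in this assay is 300 nM, with an expected range of 100 nM to 900 nM.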

Compound 4, concentration for 50% growth inhibition: 370 nM
The estimate for compound 4 lay 1.2-fold (0.09 log units) below the measured number, within the range that was stated.
By their numbers in this assay, from the lowest: compounds 3, 2, 4 and 1 (each within the scatter of the next, the first and the last beyond it).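

In this assay, the position on the aromatic carbon next to the ring nitrogen and next to the ring sulfur accepts a much larger group, (3-(dimethylamino)propyl)sulfanyl, and the series still reads within the range of its smaller members, although a 2.2-fold higher number from compound 3 to compound 4 (0.34 log units; beyond the scatter) separates this chain from dimethylamino. Extending the sulfanyl group itself, with 2-(dimethylamino)ethyl in place of hydrogen on the saturated chain carbon bound to a sulfur, gives a 1.4-fold lower number from compound 1 to compound 4 (0.16 log units; within the scatter), and the comparison with the methylamino compound gives a 1.2-fold higher number from compound 2 to compound 4 (0.09 log units; within the scatter), so in this assay the added chain separates compound 4 from neither compound 1 nor compound 2. Among the compounds shown here, the only step beyond the scatter is therefore the one from dimethylamino, and nothing at hand explains any of these steps.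

The compounds shown leave open whether the terminal dimethylamino of the chain contributes at all, which a plain butylsulfanyl chain or a terminal hydroxyl would address. They also leave open whether the sulfur link matters, which the same 3-(dimethylamino)propyl chain attached through an amine nitrogen would test.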